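The source may hold more compounds than are shown below. What is called first, only, known or untested is meant among the compounds shown, and "the series" means these compounds.

Working notes on the series. Among the compounds with values here, in an assay on U2OS cells for inhibition of secreted frizzled-related protein 1 (Homo sapiens), read by a luciferase reporter, with a stated time of 18 h (a lower number here means that less compound is needed, a higher number that more compound is needed for the effect), compound 2 `O=C(O)c1cccc(S(=O)(=O)N2CCC(NS(=O)(=O)c3cc(S(=O)(=O)c4ccccc4)ccc3C(F)(F)F)CC2)c1` gives 190 nM, the highest of the two numbers so far; compound 1 `O=C(c1cccnc1)N1CCC(NS(=O)(=O)c2cc(S(=O)(=O)c3ccccc3)ccc2C(F)(F)F)CC1` gives 120 nM, and the step of a 1.6-fold higher number from compound 1 to compound 2 (0.20 log units; within the scatter) falls within the scatter. Compound 3 `O=S(=O)(NC1CCN(S(=O)(=O)c2cccc(-c3nnn[nH]3)c2)CC1)c1cc(S(=O)(=O)c2ccccc2)ccc1C(F)(F)F` carries the change (1H-tetrazol-5-yl in place of carboxy on an aromatic carbon). Within the data shown here, no measured step touches this position: the only step seen exchanges a group on the amine nitrogen in a ring, not the carboxy. With nothing in the numbers pointing either way, compound 3 is expected to stay near compound 2, estimated at 190 nM with a range of 70 nM to 550 nM. The expected step is therefore no change at the digits printed from compound 2 to compound 3 (within the scatter), none beyond the scatter.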

Compound 3, half-maximal effective concentration: 1200 nM
For compound 3 the middle estimate is 6.3-fold (0.80 log units) below the measured one; measured number outside the range, above it.
By their numbers in this assay, from the lowest: compounds 1 and 2 (each within the scatter of the next); then compound 3.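

Within the data shown here, the aromatic carbon bearing the carboxy group is sensitive to this exchange: 1H-tetrazol-5-yl in place of carboxy gives the only step so far beyond the scatter (a 6.3-fold higher number from compound 2 to compound 3 (0.80 log units; beyond the scatter)). The earlier step (a 1.6-fold higher number from compound 1 to compound 2 (0.20 log units; within the scatter)) changed the group on the ring amine nitrogen and showed nothing about this position. No supporting data on these compounds bear on the reason for the shift. On these data alone, it remains open whether a primary amide or a methyl ester on the same carbon would stay near compound 2 or move toward compound 3.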